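The source may hold more compounds than are shown below. What is called first, only, known or untested is meant among the compounds shown, and "the series" means these compounds.

Compound 1 `Cc1c(OCCCCOc2ccccc2C(=O)O)ccc(C(=O)CC2CCCC2)c1C` reaches 28% in an assay on HEK293 cells for positive allosteric modulation of metabotropic glutamate receptor 3 (Rattus norvegicus), read by thallium flux, with a stated time of 2.5 min; a lower number here means a smaller maximal response, a higher number a larger maximal response. Compound 2 `Cc1c(OCCCCOc2ccccc2C(=O)O)ccc(C(=O)CC2CCCC2)c1O` reaches 32.9% in this assay. The two differ by hydroxy in place of methyl on an aromatic carbon, and this change gave a number 4.9 percentage points higher from compound 1 to compound 2 (within the scatter). Compound 3 `Cc1c(OCCCCOc2ccc(C(=O)O)cc2)ccc(C(=O)CC(C)C)c1C` reaches 16.6% in this assay, the lowest of the three measured numbers; its core differs from the core of compound 1, but that difference is not broken down here. Compound 4 `Cc1c(OCCCCOc2ccc(C(=O)O)cc2)ccc(C(=O)CC(C)C)c1O` has not been measured in this assay; it differs from compound 3 by hydroxy in place of methyl on an aromatic carbon. Within the data shown here, this is the same kind of change as the one from compound 1 to compound 2, though not the same: in compound 1 the exchanged position is ortho to a (cyclopentylmethyl)carbonyl group, whereas in compound 3 it is ortho to an isobutylcarbonyl group. From compound 3 to compound 4 a step of about a number 3.9 percentage points higher from compound 3 to compound 4 (within the scatter) is expected, because a number 4.9 percentage points higher from compound 1 to compound 2 (within the scatter) in the measured pair stayed within the scatter. Compound 4 is therefore estimated at 20.5% in this assay, with a likely range from 10% to 32%.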

Compound 4, largest response reached (reported as percent of maximum), in percent of the reference or control that the assay uses: 51.9%
Beside the measured number, compound 4's estimate is 31.4 percentage points below it; the measured number lies above the stated range.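

In this assay, hydroxy in place of methyl on an aromatic carbon gave a number 35.3 percentage points higher from compound 3 to compound 4 (beyond the scatter). The size of this change therefore does not carry over from one core to the other in this series, as the two steps show: the same change on two cores in this assay, a number 4.9 percentage points higher (within the scatter) from compound 1 to compound 2 and a number 35.3 percentage points higher (beyond the scatter) from compound 3 to compound 4, 30.4 percentage points apart, beyond the scatter of two such steps

The two pairs do not show which feature of the cores sets the size of the step: compound 1 and compound 3 differ in more than one place, in the (cyclopentylmethyl)carbonyl group against the isobutylcarbonyl group and in the placing of the carboxylic acid, and these differences are not separated here.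

Going by these compounds, it remains open whether the large step goes with the isobutylcarbonyl group or with the placing of the carboxylic acid, which a pair differing in only one of these would settle. Also open, on these data alone, is whether a methoxy group or an amine in place of the methyl would behave like hydroxy on either core.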